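This account rests on a few compounds, and the source may have more. Where it says the series, first, only, none or still open, it means among the compounds named here.

Measured in a functional assay on HeLa cells (Homo sapiens) for antiproliferative activity, read by MTT assay, with a stated time of 48 h; on this read-out lower numbers stand for stronger inhibition and higher numbers for weaker inhibition:
compound 1, `CC(C)[C@H](NC(=O)c1cc2ccccc2cn1)C(=O)OCc1ccccc1`: 118 nM
compound 2, `NC(=O)C[C@H](NC(=O)c1cc2ccccc2cn1)C(=O)OCc1ccccc1`: 216 nM
compound 3, `O=C(CNC(=O)c1cc2ccccc2cn1)OCc1ccccc1`: 195 nM

The three share one core and differ only in the group on the saturated chain carbon bound to an amide-type nitrogen and a carbonyl carbon. Compound 3 gives the second highest of the three numbers, yet neither gap sets it apart: the step of a 1.1-fold lower number from compound 2 to compound 3 (0.04 log units; within the scatter) and the step of a 1.7-fold higher number from compound 1 to compound 3 (0.22 log units; within the scatter) both lie within the scatter.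

Compound 4, `C[C@H](NC(=O)c1cc2ccccc2cn1)C(=O)OCc1ccccc1`, changes (methyl in place of hydrogen on a saturated chain carbon bound to an amide-type nitrogen and a carbonyl carbon). Going by the values given here, the steps that bear on this are the ones moving the same substituent. Removing isopropyl gave a 1.7-fold higher number from compound 1 to compound 3 (0.22 log units; within the scatter); swapping isopropyl for carbamoylmethyl gave a 1.8-fold higher number from compound 1 to compound 2 (0.26 log units; within the scatter); removing carbamoylmethyl gave a 1.1-fold lower number from compound 2 to compound 3 (0.04 log units; within the scatter). None of these reached beyond the scatter, and methyl is a smaller alkyl group than the isopropyl of compound 1. The expectation in this assay is therefore a step of a 1.2-fold lower number from compound 3 to compound 4 (0.07 log units; within the scatter), a slightly lower number but not one beyond the scatter. Compound 4 is estimated at 165 nM, with a range from 85 nM to 330 nM.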

Compound 4, half-maximal inhibitory concentration: 154 nM
Estimate against measurement, compound 4: 1.1-fold (0.03 log units) above; the measured number falls inside the stated range.
By their numbers in this assay, from the lowest: compounds 1, 4, 3 and 2 (each within the scatter of the next).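

In this assay, going by these compounds alone, methyl (1 heavy atom, 1 carbon, no ring) on the saturated chain carbon bound to an amide-type nitrogen and a carbonyl carbon gave a 1.3-fold lower number from compound 3 to compound 4 (0.10 log units; within the scatter), the first step here that adds a small alkyl group to the hydrogen of compound 3. The comparisons with the two larger groups agree, with a 1.3-fold higher number from compound 1 to compound 4 (0.12 log units; within the scatter) and a 1.4-fold lower number from compound 2 to compound 4 (0.15 log units; within the scatter), so hydrogen, methyl, isopropyl and carbamoylmethyl at this place now all lie within the scatter of one another, and no compound shown goes against that. No measured evidence accompanies these numbers to account for this.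

The four compounds leave open whether a group of another kind at this place, such as a carboxylic acid, an aminobutyl chain or a benzyl group, would produce a step beyond the scatter in this assay. They also leave open whether the opposite configuration at this chain carbon would give numbers like those of compound 1, compound 2 and compound 4.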